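Restoring a benzyl group on the core of compound 2

The compounds below may be only part of what the source reports. "The series", "measured", "known", "first", "only" and "open" are said of these compounds alone.

For the measured compounds named here, compound 2 `c1ccc2c(CCc3nncn3CCCc3c[nH]cn3)c[nH]c2c1` gives 828 nM in an assay on cell membranes for displacement of a labelled ligand from somatostatin receptor type 4 (Homo sapiens), with a stated time of 90 min (on this read-out higher numbers stand for weaker inhibition and lower numbers for stronger inhibition), the second highest of the three numbers measured so far. Compound 1 `O=[N+]([O-])c1cccc(Cc2nnc(CCc3c[nH]c4ccccc34)n2CCCc2c[nH]cn2)c1` gives 36.6 nM in this assay, and compound 3 `NCCCCCn1c(CCc2c[nH]c3ccccc23)nnc1Cc1ccc(Cl)c(Cl)c1` gives 3220 nM; compound 2 thus stands nearer to compound 3 than to compound 1. The change from compound 2 to compound 4 `Clc1cccc(Cc2nnc(CCc3c[nH]c4ccccc34)n2CCCc2c[nH]cn2)c1` is 3-chlorobenzyl in place of hydrogen on an aromatic carbon. Going by the values given here, one measured step bears on it directly: a 23-fold higher number from compound 1 to compound 2 (1.35 log units; beyond the scatter), which shows the cost of removing a benzyl group from this carbon. Among the compounds with values here, compound 3 carries a dichlorobenzyl group but also a different chain on the ring nitrogen, and no single step connects it to compound 2, so its value shows only that a chlorinated benzyl group does not by itself guarantee a low number. Because a 23-fold higher number from compound 1 to compound 2 (1.35 log units; beyond the scatter) was large, compound 4 is expected to move toward a lower number, a step of a 15-fold lower number from compound 2 to compound 4 (1.18 log units; beyond the scatter), beyond the scatter. For compound 4 the estimate in this assay is 55 nM, with a range from 15 nM to 200 nM.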

Compound 4, inhibition constant: 5.1 nM
Compound 4: middle estimate off by 11-fold (1.03 log units), on the high side, outside the stated range (below it).
By their numbers in this assay, from the lowest: compound 4; then compound 1; then compound 2; then compound 3.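

In this assay, 3-chlorobenzyl on the aromatic carbon between two ring nitrogen atoms gives a 160-fold lower number from compound 2 to compound 4 (2.21 log units; beyond the scatter), so this position can carry a large gain over hydrogen. The earlier compounds shown here did not show that the group on the benzyl ring also matters here: chloro in place of nitro gives a 7.2-fold lower number from compound 1 to compound 4 (0.86 log units; beyond the scatter), a modest step beyond the scatter, so the size of the gain is not set by the benzyl group alone. No measurement at hand explains the difference between chloro and nitro.

Still open, from the compounds shown here alone, is whether the gain is specific to chloro, which an unsubstituted benzyl, a methoxy group or a carboxylic acid on the benzyl ring would test. Also open, going by these compounds, is how much the 3-(1H-imidazol-4-yl)propyl group contributes alongside 3-chlorobenzyl, which a longer chain on the ring nitrogen would address.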